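The source may report more compounds than this note shows. Statements on the series, on what has been measured and on what is new or still open speak of the compounds shown alone.

Of the compounds shown here, three built on one shared core have so far been tested in a functional assay on PC-9 cells (Homo sapiens) for inhibition, read by MTT assay, with a stated time of 72 h; on this read-out lower numbers stand for stronger inhibition and higher numbers for weaker inhibition. Compound 1 `Cc1cc(Nc2cc(-c3ccccc3)[nH]n2)n2nc(SCC(=O)c3ccccc3)nc2n1` gives 4450 nM. Compound 2 `Cc1cc(Nc2ccn(Cc3ccc(F)cc3)n2)n2nc(SCc3ccc(Br)cc3)nc2n1` gives 19400 nM. Compound 3 `Cc1cc(Nc2ccn(Cc3csc4ccc(Cl)cc34)n2)n2nc(SCc3ccc(Br)cc3)nc2n1` gives 4350 nM. Among these three numbers compound 1 stands second highest: its number and that of compound 3 lie within the usual scatter of each other, whereas compound 2 shows a number that sits beyond the scatter above compound 1. Going by the values given here, the only step measured between two compounds that differ in a single place is a 4.5-fold lower number from compound 2 to compound 3 (0.65 log units; beyond the scatter).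

Compound 4 `CCCSc1nc2nc(C)cc(Nc3cc(-c4ccccc4)[nH]n3)n2n1` has not yet been measured. It differs from compound 1 in one place: ethyl in place of benzoyl on a saturated chain carbon bound to a sulfur. Among the compounds with values here, this alteration is made on a saturated chain carbon bound to a sulfur, a part of the molecule untouched in the step between compound 2 and compound 3, so that step gives no direct guide, and no other measured pair shares the change. The data therefore offer no ground for expecting a shift beyond the scatter in either direction, even though a six-membered aromatic ring leaves and only a short chain enters. The expected step is accordingly a 1.3-fold higher number from compound 1 to compound 4 (0.13 log units; within the scatter). Compound 4 is estimated at 6000 nM, within a range from 2000 nM to 20000 nM.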

Compound 4, half-maximal inhibitory concentration: > 50000 nM
Compound 4 ended at the assay's limit; the forecaster's own chance of this, stated with the estimate: 10%; middle value at least 8.3-fold (0.92 log units) from the limit.
By their numbers in this assay, from the lowest: compounds 3 and 1 (each within the scatter of the next); then compound 2. At a limit, above all of these: compound 4.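

The change on the saturated chain carbon bound to a sulfur is far from neutral in this assay: ethyl in place of benzoyl gives an at least 11-fold higher number from compound 1 to compound 4 (1.05 log units; beyond the scatter). The earlier compounds shown here offered no measured step at this place, and this one shows that the group carried there matters a great deal for the read-out, at least on the core of compound 1, where the inhibition seen with benzoyl does not survive the swap to ethyl. The value of compound 4 is a limit and not a number: the limit of > 50000 nM in this assay, at which 1 of the 4 values shown sits.

What remains open is which part of the benzoyl group counts, since the six-membered aromatic ring and the carbonyl leave together in this one change, and the compounds shown cannot tell them apart. An acetyl group at this place would keep the carbonyl without the ring, a phenyl group would keep the ring without the carbonyl, and a longer chain such as hexyl would show whether sheer length on the sulfur can stand in for either.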